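The source may report more compounds than this note shows. Statements on the series, on what has been measured and on what is new or still open speak of the compounds shown alone.

Measured so far: compound 1 `Cc1cc(Cl)c(S(C)(=O)=O)cc1C(=O)N=C(N)N` with 25 nM in a functional assay for inhibition of sodium/hydrogen exchanger (Oryctolagus cuniculus) (on this read-out higher numbers stand for weaker inhibition and lower numbers for stronger inhibition), and compound 2 `Cc1cc(Sc2ccc(Cl)cc2)c(S(C)(=O)=O)cc1C(=O)N=C(N)N` with 19 nM in this assay.

Compound 2 has the lowest of the two numbers in this assay, but its nearest neighbour, compound 1, lies within the scatter. Compound 3 `Cc1cc(OC2CCCC2)c(S(C)(=O)=O)cc1C(=O)N=C(N)N` differs from compound 2 by cyclopentyloxy in place of (4-chlorophenyl)sulfanyl on an aromatic carbon. Among the compounds with values here, the one step that bears on this position, a 1.3-fold lower number from compound 1 to compound 2 (0.12 log units; within the scatter), stayed within the scatter, so the substituent at this place has so far made no visible difference. Compound 3 is therefore expected to give about 25 nM in this assay, between 8 nM and 80 nM. The expected step from compound 2 is a 1.3-fold higher number from compound 2 to compound 3 (0.12 log units; within the scatter), which is estimated to lie within the scatter.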

Compound 3, half-maximal inhibitory concentration: 27 nM
Compound 3: the middle estimate sits 1.1-fold (0.03 log units) below what was measured; measured number inside the range.
By their numbers in this assay, from the lowest: compounds 2, 1 and 3 (each within the scatter of the next).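

At the aromatic carbon ortho to a methylsulfonyl group, cyclopentyloxy now stands alongside chloro and (4-chlorophenyl)sulfanyl with no visible difference in this assay: replacing the (4-chlorophenyl)sulfanyl gives a 1.4-fold higher number from compound 2 to compound 3 (0.15 log units; within the scatter) and replacing the chloro gives a 1.1-fold higher number from compound 1 to compound 3 (0.03 log units; within the scatter). Both steps stay within the scatter, so an oxygen-linked non-aromatic ring fits this place as well as a sulfur-linked aromatic ring or a single chlorine. Nothing available explains this flat result.

From the compounds shown here alone, whether an amine or a carboxylic acid at this place would move the number beyond the scatter stays open. So does whether this flat picture would hold with other changes on the shared core.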